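This account rests on a few compounds, and the source may have more. Where it says the series, first, only, none or still open, it means among the compounds named here.

Measured so far in a functional assay on MGC-803 cells (Homo sapiens) for cytotoxicity, read by MTT assay, with a stated time of 48 h; a lower number here means a stronger inhibitor, a higher number a weaker inhibitor:
compound 1, `CC1=NN(S(=O)(=O)c2ccc([N+](=O)[O-])cc2)C(c2cc(Br)cc(Br)c2O)C1`, gives 40100 nM
compound 2, `CC(=O)Oc1ccccc1C1CC(C)=NN1C(=O)CN1CCC(O)CC1`, gives 3510 nM
compound 3, `O=C(c1ccccc1)N1N=C(c2cc3ccccc3oc2=O)CC1c1ccccc1`, gives 12700 nM

Compound 3 stands at the second highest of the three numbers: compound 1 lies at a higher number, beyond the scatter, and compound 2 at a lower number, also beyond the scatter. Compound 4, `CC1CC(C)CN(CC(=O)N2N=C(c3cc4ccccc4oc3=O)CC2c2ccccc2)C1`, has not yet been tested in this assay. It differs from compound 3 in one place: (3,5-dimethylpiperidin-1-yl)methyl in place of phenyl on a carbonyl carbon. Going by the values given here, no measured pair shows this change, so its effect is not known from these data. Because compound 2 gives 3510 nM with an acyl side chain built in a related way, a lower number is anticipated for compound 4. The expected step is a 2.1-fold lower number from compound 3 to compound 4 (0.33 log units; beyond the scatter), modest and toward a lower number, around the edge of the scatter. Compound 4 is therefore expected to give 6000 nM, within 2000 nM to 18000 nM.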

Compound 4, half-maximal inhibitory concentration: "not active" (no number reported)
For compound 4 the study gives words and no number; the estimate stays without a comparison.
By their numbers in this assay, from the lowest: compound 2; then compound 3; then compound 1.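

In this assay, going by these compounds alone, compound 4 is reported only as not active, without a number, so no step from compound 3 to compound 4 can be read. The compounds shown leave open how far replacing phenyl with (3,5-dimethylpiperidin-1-yl)methyl shifts the value. Nothing shown here accounts for this result.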